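Chloro to amino on compound 1: working notes

The compounds below may be only part of what the source reports. "The series", "measured", "known", "first", "only" and "open" are said of these compounds alone.

In a functional assay on KB cells (Homo sapiens) for antiproliferative activity, read by colorimetric assay and MTT assay (a lower number here means a stronger inhibitor, a higher number a weaker inhibitor), compound 2 (`O=[N+]([O-])c1ccc(S(=O)(=O)Nc2cccc3c(Cl)c[nH]c23)cc1`) gives 14 ug/mL and compound 1 (`O=S(=O)(Nc1cccc2cc(O)[nH]c12)c1ccc(Cl)cc1`) gives 1.1 ug/mL as the lower of the two numbers, a gap beyond the scatter. Compound 3 (`Nc1ccc(S(=O)(=O)Nc2cccc3cc(O)[nH]c23)cc1`) differs from compound 1 by amino in place of chloro on an aromatic carbon (amino in place of chloro on an aromatic carbon, para to a large group). For the measured compounds named here, no measured pair isolates this change, so the size of the step in this assay remains open. The expected step of a 1.4-fold lower number from compound 1 to compound 3 (0.14 log units; within the scatter) is slight, toward a lower number and not beyond the scatter. Compound 3 is estimated at 0.8 ug/mL (expected range 0.15 ug/mL to 4 ug/mL).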

Compound 3, half-maximal inhibitory concentration: 0.86 ug/mL
For compound 3 the middle estimate is 1.1-fold (0.03 log units) below the measured one; measured number inside the range.
By their numbers in this assay, from the lowest: compounds 3 and 1 (each within the scatter of the next); then compound 2.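

In this assay, for the compounds shown here, the change from chloro to amino gives a 1.3-fold lower number from compound 1 to compound 3 (0.11 log units; within the scatter) as the first measured pair at this position. On the shared core, 4-chlorophenyl and 4-aminophenyl therefore cannot be told apart here, although amino carries hydrogen-bond donor and acceptor counts that chloro lacks. Nothing measured here accounts for this result. As far as these compounds go, whether a carboxylic acid, a methoxy group or a dimethylamino group at this position would stay level with compound 1 remains open. Going by these compounds alone, compound 2 differs from compound 1 and compound 3 in more than one place, so no step to it can be read.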